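The source may hold more compounds than are shown below. What is called first, only, known or untested is meant among the compounds shown, and "the series" means these compounds.

Measured compounds:
compound 1 `Oc1ccc(CC[C@@H]2C[C@@H](O)C[C@H](c3ccc(O)c(O)c3)O2)cc1` — 27900 nM
compound 2 `COc1cc([C@@H]2O[C@H]([C@@H](O)Cc3ccc(O)cc3)C[C@@H](O)[C@@H]2O)ccc1O` — > 100000 nM

Of the compounds shown here, two have been measured in a functional assay on RAW264.7 cells (Mus musculus) for inhibition, read by Griess assay, with a stated time of 24 h; on this read-out higher numbers stand for weaker inhibition and lower numbers for stronger inhibition. Compound 1 has the only number shown, a half-maximal inhibitory concentration of 27900 nM. For compound 2 the read-out is a limit of the assay, not a number: > 100000 nM, a result that falls at the limit of > 100000 nM in this assay, at which 1 of the 2 values shown sits. Among the compounds with values here, with no step between two measured compounds that differ in only one place, there is no measured guide to how a single change moves this read-out.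

Compound 3 `OC[C@H]1O[C@@H](O[C@@H]2C[C@@H](CCc3ccc(O)cc3)O[C@@H](c3ccc(O)c(O)c3)C2)[C@H](O)[C@@H](O)[C@@H]1O` is not yet measured. It differs from compound 1 in one place: 3,4,5-trihydroxy-6-(hydroxymethyl)oxan-2-yl in place of hydrogen on an oxygen on a saturated carbon. The sugar-like ring is attached to the oxygen of a hydroxyl group on the core of compound 1.

Without a measured step, the expectation rests only on the value of compound 1 and on the size of the added group. A modest loss of inhibition in this assay is expected, so the step of a 2.0-fold higher number from compound 1 to compound 3 (0.29 log units; within the scatter) is expected to lie somewhat beyond the scatter, toward weaker inhibition. Compound 3 is therefore estimated at 55000 nM, within a range of 15000 nM to 150000 nM.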

Compound 3, half-maximal inhibitory concentration: 79900 nM
Compound 3: the middle estimate sits 1.5-fold (0.16 log units) below what was measured, within the range that was stated.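

Within the data shown here, this is the first step in this assay between two compounds that differ in only one place, so one change now has a measured size. Placing 3,4,5-trihydroxy-6-(hydroxymethyl)oxan-2-yl in place of hydrogen on an oxygen on a saturated carbon gives a 2.9-fold higher number from compound 1 to compound 3 (0.46 log units; beyond the scatter). At this position, a group of 11 heavy atoms therefore weakens inhibition only modestly, and compound 3 still gives a number instead of joining the one compound that reaches a limit of the read-out: the limit of > 100000 nM in this assay, at which 1 of the 3 values shown sits.

The compounds shown cannot separate the effect of this sugar-like ring from the effect of simply replacing the hydrogen on that oxygen, and these values do not give a cause for the weaker inhibition. A methyl or an acetyl group on the same oxygen would show whether any replacement brings a similar step or whether it belongs to the 3,4,5-trihydroxy-6-(hydroxymethyl)oxan-2-yl group in particular.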